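Compound 2 to compound 4: methoxy in place of chloro

The source may report more compounds than this note shows. Statements on the series, on what has been measured and on what is new or still open speak of the compounds shown alone.

Measured in a functional assay on T47D cells (Homo sapiens) for inhibition, read by CCK-8 assay, with a stated time of 72 h, tested at 1 uM; a lower number here means less inhibition of growth, a higher number more inhibition of growth at the concentration tested:
- compound 1 `CN(C)C(=O)c1cc2cnc(Nc3ccc(NC(=O)C4(C(=O)Nc5ccc(F)cc5)CC4)cc3)nc2n1C1CCCC1`: 74.7%
- compound 2 `CN(C)C(=O)c1cc2cnc(Nc3ccc(NC(=O)C4(C(=O)Nc5cccc(Cl)c5)CC4)cc3)nc2n1C1CCCC1`: 39.3%
- compound 3 `Nc1ccc(NC(=O)C2(C(=O)Nc3ccc(F)cc3)CC2)cc1F`: 5.6%

Not yet measured: compound 4 `COc1cccc(NC(=O)C2(C(=O)Nc3ccc(Nc4ncc5cc(C(=O)N(C)C)n(C6CCCC6)c5n4)cc3)CC2)c1`.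

Compound 2, with 39.3%, holds the middle place of the three, and its gaps to compound 1 and compound 3 both lie beyond the scatter. Compound 4 differs from it by one change: methoxy in place of chloro on an aromatic carbon.

Within the data shown here, one measured step bears on this: a number 35.4 percentage points lower from compound 1 to compound 2 (beyond the scatter), a large step with 3-chlorophenyl in place of 4-fluorophenyl on an amide-type nitrogen. Among the measured compounds shown here, it shows that this assay can respond to a change in this group, but no measured compound carries methoxy, so its direction cannot be carried over. For the measured compounds named here, compound 3 differs from compound 2 in more than one place and gives no step. No step beyond the scatter is expected, though since compound 1 reaches 74.7% with another group on this nitrogen, the expected range stays wide.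

For compound 4 the estimated change is a number 4.7 percentage points higher from compound 2 to compound 4 (within the scatter). The expected value for compound 4 is 44%, with an estimated range of 25% to 65%.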

Compound 4, percent growth inhibition at one concentration: 56.3%
Compound 4: middle estimate off by 12.3 percentage points, on the low side, within the range that was stated.
By their numbers in this assay, from the lowest: compound 3; then compound 2; then compound 4; then compound 1.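

In this assay, the group on this aromatic carbon changes the read-out even when the ring position stays the same: methoxy in place of chloro gives a number 17 percentage points higher from compound 2 to compound 4 (beyond the scatter) and shows that the earlier loss with 3-chlorophenyl is not fixed by the position alone. The 3-methoxyphenyl group still gives a number 18.4 percentage points lower from compound 1 to compound 4 (beyond the scatter) and so recovers only part of that loss relative to 4-fluorophenyl. Nothing available explains why methoxy and chloro differ here.

From the compounds shown here alone, whether a hydroxyl, an amine or a carboxylic acid on this aromatic carbon would match or pass methoxy remains open. So does the outcome with a longer chain such as ethoxy, and these compounds do not settle whether the read-out tracks the oxygen or the size of the group.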